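Swapping the benzyl ring substituent in a weak inhibitor

The source may hold more compounds than are shown below. What is called first, only, known or untested is meant among the compounds shown, and "the series" means these compounds.

Compound 1 `CCOC(=O)c1c(C)nc(-c2cccc(C#N)c2)n1OCCC(=O)O` — > 30000 nM (a limit)
Compound 2 `CCOC(=O)c1c(C)nc(-c2cccc(C#N)c2)n1OCc1cccc(F)c1` — 22400 nM

In a functional assay on a cell-free system (plasma, Oryctolagus cuniculus) for inhibition, with stated times of 5 min, 1 min and 6 min (a higher number here means a weaker inhibitor, a lower number a stronger inhibitor), compound 1 returns only a limit, > 30000 nM. Compound 1 therefore sits at the limit of > 30000 nM in this assay, at which 1 of the 2 values shown sits. For the measured compounds named here, compound 2 gives 22400 nM, the only true number among the two values, and the one step that can be read is an at least 1.3-fold lower number from compound 1 to compound 2 (0.12 log units; that floor lies within the scatter), which comes from exchanging 3-fluorophenyl for carboxymethyl on a saturated chain carbon bound to an oxygen on an aromatic ring.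

Compound 3 `CCOC(=O)c1c(C)nc(-c2cccc(C#N)c2)n1OCc1ccc(C)cc1` differs from compound 2 by 4-methylphenyl in place of 3-fluorophenyl on a saturated chain carbon bound to an oxygen on an aromatic ring. Going by the values given here, the sole measured step touches the same place, but it only sets a floor that lies inside the scatter, so it gives no guide to direction or size for a ring-substituent swap of this kind. Compound 3 is therefore expected to stay close to compound 2 in this assay, with no step beyond the scatter: the estimated change is a 1.1-fold higher number from compound 2 to compound 3 (0.05 log units; within the scatter). Compound 3 is estimated at 25000 nM, with a range from 8000 nM to 80000 nM.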

Compound 3, half-maximal inhibitory concentration: 6310 nM
Estimate against measurement, compound 3: 4.0-fold (0.60 log units) above, and the stated range ends above it.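

In this assay, for the compounds shown here, 4-methylphenyl in place of 3-fluorophenyl on the saturated chain carbon bound to an oxygen on an aromatic ring gives a 3.5-fold lower number from compound 2 to compound 3 (0.55 log units; beyond the scatter), the first step at this place that clears the scatter, and it shows that the number responds to the aryl group here even though the two groups have the same counts of heavy atoms, donors and acceptors. Measured against the carboxymethyl group of compound 1, the same 4-methylphenyl gives an at least 4.7-fold lower number from compound 1 to compound 3 (0.67 log units; beyond the scatter), so a step from that group can now be read beyond the scatter, though only as a floor. Compound 1 itself remains a limit: the limit of > 30000 nM in this assay, at which 1 of the 3 values shown sits.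

As far as these compounds go, what stays open is whether the step follows from the change of substituent or from its place on the ring, since the names 3-fluorophenyl and 4-methylphenyl differ in both, and 4-fluorophenyl or 3-methylphenyl would separate the two. Also open, from the compounds shown here alone, is how an unsubstituted phenyl ring, or a ring carrying an amine, would read at this place.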